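Oxazolidinone side-chain variants: cytotoxicity notes

The source may hold more compounds than are shown below. What is called first, only, known or untested is meant among the compounds shown, and "the series" means these compounds.

Measured so far:
- compound 1 `O=C1CCC(=O)N1C[C@H]1CN(c2ccc(-n3cc(-c4ccccn4)cn3)c(F)c2)C(=O)O1`: in an ADME assay on HEK293-A cells (Homo sapiens) for cytotoxicity, read by MTT assay, with a stated time of 48 h (a higher number here means a weaker inhibitor, a lower number a stronger inhibitor), compound 1 gives > 400 ug/mL, which is a limit of the assay and not a number.
- compound 2 `O=C1O[C@@H](Cn2ccnn2)CN1c1ccc(-n2cc(-c3ccccn3)cn2)c(F)c1`: in this assay compound 2 gives 225 ug/mL.
- compound 3 `CN(C)S(=O)(=O)NC[C@H]1CN(c2ccc(-n3cc(-c4ccccn4)cn3)c(F)c2)C(=O)O1`: in this assay compound 3 gives 249 ug/mL.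

For the measured compounds named here, compound 3 holds the highest of the two numbers known; its nearest neighbour is compound 2, and a 1.1-fold higher number from compound 2 to compound 3 (0.04 log units; within the scatter). Against compound 1 only a floor can be stated, because compound 1 sits at the limit of > 400 ug/mL in this assay, at which 1 of the 3 values shown sits; hence an at least 1.7-fold lower number from compound 1 to compound 2 (0.24 log units; that floor lies within the scatter) and an at least 1.6-fold lower number from compound 1 to compound 3 (0.20 log units; that floor lies within the scatter).

Compound 4 `CNC(=O)[C@H]1CN(c2ccc(-n3cc(-c4ccccn4)cn3)c(F)c2)C(=O)O1` is the next variant: methylcarbamoyl in place of ((dimethylsulfamoyl)amino)methyl on a saturated ring carbon. Going by the values given here, none of the measured steps touches this position; all three swap the pendant group on the chain carbon while keeping the chain, and none of them moves beyond the scatter. The change to compound 4 removes the chain itself, so the measured steps bear on it only indirectly, as a sign that this side of the shared core has so far been tolerant.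

On that basis no step beyond the scatter is expected in this assay, and compound 4 is estimated at 250 ug/mL, between 120 ug/mL and 400 ug/mL, which means an expected step of a 1.0-fold higher number from compound 3 to compound 4 (0.00 log units; within the scatter).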

Compound 4, half-maximal inhibitory concentration: 342 ug/mL
For compound 4 the middle estimate is 1.4-fold (0.14 log units) below the measured one; low and high end bracket the measured number.
By their numbers in this assay, from the lowest: compounds 2, 3 and 4 (each within the scatter of the next). At a limit, above all of these: compound 1.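

For the compounds shown here, compound 4 is the first variant to lose the chain carbon, placing methylcarbamoyl directly on the saturated ring carbon next to the ring oxygen, and the change in this assay remains small: a 1.4-fold higher number from compound 3 to compound 4 (0.14 log units; within the scatter). The earlier steps shown here changed only the pendant group on a retained chain, whereas this result shows that neither the chain nor the ((dimethylsulfamoyl)amino)methyl group is needed for a value in the same range, and the comparison with the (1H-1,2,3-triazol-1-yl)methyl variant agrees: a 1.5-fold higher number from compound 2 to compound 4 (0.18 log units; within the scatter). The (2,5-dioxopyrrolidin-1-yl)methyl variant gives only a floor, an at least 1.1-fold lower number from compound 1 to compound 4 (0.06 log units; that floor lies within the scatter), because compound 1 sits at: the limit of > 400 ug/mL in this assay, at which 1 of the 4 values shown sits.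

Still open, going by these compounds, is whether a carboxylic acid or a primary amine on this saturated ring carbon, or a longer chain carrying the methylcarbamoyl group, would also stay within the scatter of compound 4 in this assay. All four compounds keep the shared core unchanged, so its part in these closely grouped numbers remains unresolved.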